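Sulfonyl aryl variation in a kallikrein-7 inhibitor series

The compounds below may be only part of what the source reports. "The series", "measured", "known", "first", "only" and "open" are said of these compounds alone.

Compound 1 `CC1=NC(c2cn(S(=O)(=O)c3ccccc3)c3ccc(C)cc23)CN1` gives 15000 nM in an assay on isolated protein for inhibition of kallikrein-7 (Mus musculus), read by fluorescence, with stated times of 10 min and 30 min; on this read-out lower numbers stand for stronger inhibition and higher numbers for weaker inhibition. Compound 2 `CC1=NC(c2cn(S(=O)(=O)c3cccs3)c3ccc(C)cc23)CN1` gives 22000 nM in this assay. Compound 3 `CC1=NC(c2cn(S(=O)(=O)c3ccccc3Br)c3ccc(C)cc23)CN1` gives 400 nM in this assay.

Compound 3 stands lowest of the three numbers in this assay; compound 1 is nearest, with a 38-fold lower number from compound 1 to compound 3 (1.57 log units; beyond the scatter) separating them, and compound 2 is furthest, with a 55-fold lower number from compound 2 to compound 3 (1.74 log units; beyond the scatter). The change from compound 1 to compound 2, a 1.5-fold higher number from compound 1 to compound 2 (0.17 log units; within the scatter), lies within the scatter.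

Compound 4 `CC1=NC(c2cn(S(=O)(=O)c3c(Cl)cccc3Cl)c3ccc(C)cc23)CN1` differs from compound 3 in one place: 2,6-dichlorophenyl in place of 2-bromophenyl on a sulfonyl sulfur. For the measured compounds named here, the step that bears most directly on it is the one from compound 1 to compound 3, a 38-fold lower number from compound 1 to compound 3 (1.57 log units; beyond the scatter), where a single halogen on the phenyl of the sulfonyl brought a large drop in the number. Going by the values given here, compound 4 keeps halogen on that phenyl and adds a second; no measured step shows what a second halogen does. The expectation is therefore that compound 4 stays near compound 3, with at most a modest lowering, a 1.6-fold lower number from compound 3 to compound 4 (0.20 log units; within the scatter). Compound 4 is estimated at 250 nM in this assay, with a range from 60 nM to 1200 nM.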

Compound 4, half-maximal inhibitory concentration: 10000 nM
Compound 4: the middle estimate sits 40-fold (1.60 log units) below what was measured, and the stated range ends below it.
By their numbers in this assay, from the lowest: compound 3; then compounds 4, 1 and 2 (each within the scatter of the next, the first and the last beyond it).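

Halogen on the phenyl of the sulfonyl does not by itself carry the gain seen with compound 3 in this assay: 2,6-dichlorophenyl in place of 2-bromophenyl gives a large step (a 25-fold higher number from compound 3 to compound 4 (1.40 log units; beyond the scatter)), which removes that gain. Measured against the plain phenyl group, the 2,6-dichlorophenyl group cannot be told apart (a 1.5-fold lower number from compound 1 to compound 4 (0.18 log units; within the scatter)), and against thiophen-2-yl it shows only a modest difference (a 2.2-fold lower number from compound 2 to compound 4 (0.34 log units; beyond the scatter)), so the gain belongs to the 2-bromophenyl group alone among these compounds. No measurement at hand explains this reversal.

The change swaps bromine for chlorine and also brings a second halogen, and the compounds shown do not separate these two parts. A 2-chlorophenyl or 2,6-dibromophenyl group on the sulfonyl sulfur would tell them apart, and a 2-methylphenyl group would ask whether a halogen is needed at all.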